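Phenyl for Thiophene on the Shared Core

The source may report more compounds than this note shows. Statements on the series, on what has been measured and on what is new or still open speak of the compounds shown alone.

Of the compounds shown here, three have been measured in a functional assay on HL-60 cells (Homo sapiens) for antiproliferative activity, read by XTT assay, with a stated time of 72 h; on this read-out higher numbers stand for weaker inhibition and lower numbers for stronger inhibition. Compound 1 `O=c1[nH]cnc2c1c(-c1ccoc1)cn2[C@@H]1O[C@H](CO)[C@@H](O)[C@H]1O` gives 6370 nM in this assay. Compound 2 `O=c1[nH]cnc2c1c(-c1ccsc1)cn2[C@@H]1O[C@H](CO)[C@@H](O)[C@H]1O` gives 12000 nM, which is the highest of the three numbers; its nearest neighbour is compound 1, and the step of a 1.9-fold higher number from compound 1 to compound 2 (0.28 log units; within the scatter) lies within the scatter. Compound 3 `COc1ncnc2c1c(I)cn2[C@@H]1O[C@H](CO)[C@@H](O)[C@H]1O`, built on a different core, gives 2300 nM, a number beyond the scatter from compound 2 but not joined to it by a single-point step.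

Compound 4 `O=c1[nH]cnc2c1c(-c1ccccc1)cn2[C@@H]1O[C@H](CO)[C@@H](O)[C@H]1O` has not yet been measured. It differs from compound 2 by phenyl in place of thiophen-3-yl on an aromatic carbon. Among the compounds with values here, the only measured step that bears on this change is the exchange of one five-membered ring for another, from compound 1 to compound 2, and it stayed within the scatter. The data therefore give no ground to expect a step beyond the scatter in this assay in either direction when the thiophen-3-yl ring is exchanged for phenyl. Compound 4 is estimated at 9000 nM, with a range from 3000 nM to 27000 nM, so that the expected step is a 1.3-fold lower number from compound 2 to compound 4 (0.12 log units; within the scatter).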

Compound 4, half-maximal inhibitory concentration: > 20000 nM
Compound 4: a limit, no number; the forecaster's own chance of this, stated with the estimate: 5%; at least 2.2-fold (0.34 log units) between middle value and limit.
By their numbers in this assay, from the lowest: compound 3; then compounds 1 and 2 (each within the scatter of the next). At a limit, above all of these: compound 4.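

At the aromatic carbon two ring bonds from the ring nitrogen, compound 4, with its phenyl ring, gives a limit and not a number in this assay: the limit of > 20000 nM in this assay, at which 1 of the 4 values shown sits. Measured against thiophen-3-yl, the change gives an at least 1.6-fold higher number from compound 2 to compound 4 (0.22 log units; that floor lies within the scatter), so its floor does not separate the two groups, whereas against furan-3-yl it gives an at least 3.1-fold higher number from compound 1 to compound 4 (0.49 log units; beyond the scatter). The exchange of one five-membered ring for another had stayed within the scatter, so phenyl in place of furan-3-yl is the first change among these compounds at this position with a step beyond it.

The compounds on the shared core carry only aromatic rings at this carbon, which leaves open how an amine, a carboxylic acid or a longer alkyl chain would read there. Also open, on these data alone, is whether phenyl would give a comparable step on the core of compound 3.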